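A few compounds are considered here, and "the series" means these few. Any claim that something is new, unique, unknown or untested is made for them only; others in the source may bear on it.

Compound 1 `CN(c1ccc2[nH]c(-c3n[nH]c4ccccc34)cc2n1)S(=O)(=O)c1ccc(Cl)cc1`: 18200 nM
Compound 2 `CN(c1ccc2[nH]c(-c3n[nH]c4ccccc34)cc2n1)S(=O)(=O)c1ccc(Br)cc1`: 19700 nM

Both values come from a functional assay on A549 cells (Homo sapiens) for antiproliferative activity, read by MTT assay, with a stated time of 72 h; on this read-out lower numbers stand for stronger inhibition and higher numbers for weaker inhibition. Among the measured compounds shown here, compound 2 gives the highest of the two numbers, with compound 1 nearest; the only measured step, a 1.1-fold higher number from compound 1 to compound 2 (0.03 log units; within the scatter), is a halogen swap. Compound 3 `COc1ccc(S(=O)(=O)N(C)c2ccc3[nH]c(-c4n[nH]c5ccccc45)cc3n2)cc1OC` differs from compound 2 in one place: 3,4-dimethoxyphenyl in place of 4-bromophenyl on a sulfonyl sulfur. For the measured compounds named here, no measured step covers this change, and the halogen step is too small to point a direction, so no shift beyond the scatter is expected. Compound 3 is estimated at 16000 nM, range 4000 nM to 60000 nM, meaning an expected step of a 1.2-fold lower number from compound 2 to compound 3 (0.09 log units; within the scatter).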

Compound 3, half-maximal inhibitory concentration: > 50000 nM
Compound 3 gave a limit, no number; the forecaster's own chance of this, stated with the estimate: 15%; at least 3.1-fold (0.49 log units) between middle value and limit.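

Compound 3 gives a limit and not a number: the limit of > 50000 nM in this assay, at which 1 of the 3 values shown sits. Even so, the group on the sulfonyl sulfur proves able to move the read-out towards weaker inhibition, with an at least 2.5-fold higher number from compound 2 to compound 3 (0.40 log units; beyond the scatter) and an at least 2.7-fold higher number from compound 1 to compound 3 (0.43 log units; beyond the scatter). Unlike the halogen step, which stays within the scatter, these steps lie beyond it.

On these data alone, the full size of the shift stays open, as does whether either methoxy group alone accounts for it. Also open, as far as these compounds go, is how a phenyl bearing an amine or a carboxylic acid would read on the sulfonyl sulfur.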